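Chain-end aryl replacement on the sulfoxide acid series

The source may report more compounds than this note shows. Statements on the series, on what has been measured and on what is new or still open speak of the compounds shown alone.

Among the compounds with values here, compound 1 `CCCCCCCCCCCCOc1ccc(C[S+]([O-])c2cccc(C(=O)O)c2)nc1/C=C/C(=O)O` gives the lowest of the two numbers measured so far in an assay for binding affinity to leukotriene B4 receptor 1 (Homo sapiens) (a lower number here means a stronger inhibitor, a higher number a weaker inhibitor), where compound 1 reaches 129 nM. Within the data shown here, its only measured neighbour, compound 2 `CCCCCCCCCCCCOc1ccc(C[S+]([O-])c2ccc(C(=O)O)cc2)nc1/C=C/C(=O)O`, carries 4-carboxyphenyl in place of 3-carboxyphenyl on the sulfur; in this assay compound 2 gives 252 nM. Among the measured compounds shown here, the one recorded step, a 2.0-fold higher number from compound 1 to compound 2 (0.29 log units; within the scatter), stays within the scatter, so the position of the carboxyl on the sulfur-bound ring shows no clear effect at this level.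

Compound 3 `COc1ccc(CCCCCCCCOc2ccc(C[S+]([O-])c3cccc(C(=O)O)c3)nc2/C=C/C(=O)O)cc1` keeps the whole sulfoxide and acid portion of compound 1 and alters only the saturated chain: 4-methoxyphenyl in place of butyl on a saturated chain carbon, eight bonds along the chain from an oxygen on an aromatic ring. For the measured compounds named here, no measured step touches this chain; the step from compound 1 to compound 2 concerns the ring on sulfur alone and offers no guidance for the chain. With nothing in the set pointing up or down, the expected step of a 1.0-fold higher number from compound 1 to compound 3 (0.00 log units; within the scatter) is set near nil, any real shift being undecided and plausibly within the scatter. Compound 3 is accordingly estimated at 130 nM, with a range from 40 nM to 450 nM in this assay.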

Compound 3, inhibition constant: 151 nM
The estimate for compound 3 lay 1.2-fold (0.07 log units) below the measured number; the range from low to high includes it.
By their numbers in this assay, from the lowest: compounds 1, 3 and 2 (each within the scatter of the next).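

Putting 4-methoxyphenyl in place of butyl, on a saturated chain carbon, eight bonds along the chain from an oxygen on an aromatic ring, gives a 1.2-fold higher number from compound 1 to compound 3 (0.07 log units; within the scatter) in this assay. Within the data shown here, this is the first measured change at the chain end, and it shows that a six-membered aromatic ring of carbon only, with its methoxy oxygen, can replace the end of the saturated chain with no clear shift in this assay, so an all-carbon saturated end is not needed to stay in the range of compound 1. No supporting measurement bears on why the two chain ends read alike.

One aryl end group on one chain length cannot define what this position accepts: an unsubstituted phenyl would separate the ring from its methoxy group, while a terminal amine, a carboxylic acid or a longer chain ahead of the 4-methoxyphenyl would test the position more widely. Also open, on these data alone, is whether 4-methoxyphenyl at the chain end reads the same when 4-carboxyphenyl replaces 3-carboxyphenyl on the sulfur.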